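The source may report more compounds than this note shows. Statements on the series, on what has been measured and on what is new or still open speak of the compounds shown alone.

Compound 3 `N#CC1=C(NS(=O)(=O)c2ccc([N+](=O)[O-])cc2)N(c2ccc(S(N)(=O)=O)cc2)C2=C(C(=O)CCC2)C1c1ccc(Cl)cc1Cl` stands second highest of the three values in a functional assay on Ehrlich cells (Mus musculus) for cytotoxicity, read by trypan blue exclusion, with a stated time of 2 h, tested at 100 ug/mL (a lower number here means a weaker effect, a higher number a stronger effect of the compound at the concentration tested), where compound 3 gives 90%. Compound 1 `N#CC1=C(NC(=S)Nc2ccc(Cl)cc2)N(c2ccc(S(N)(=O)=O)cc2)C2=C(C(=O)CCC2)C1c1ccc(Cl)cc1Cl` gives 100%, and compound 2 `N#CC1=C(NC(N)=O)N(c2ccc(S(N)(=O)=O)cc2)C2=C(C(=O)CCC2)C1c1ccc(Cl)cc1Cl` gives 60%. The step of a number 10 percentage points lower from compound 1 to compound 3 (within the scatter) lies within the scatter, whereas a number 30 percentage points higher from compound 2 to compound 3 (beyond the scatter) and a number 40 percentage points lower from compound 1 to compound 2 (beyond the scatter) lie beyond it; all three exchange the whole group on the amine nitrogen. Compound 4 `N#CC1=C(NS(=O)(=O)c2ccc(Br)cc2)N(c2ccc(S(N)(=O)=O)cc2)C2=C(C(=O)CCC2)C1c1ccc(Cl)cc1Cl` differs from compound 3 by bromo in place of nitro on an aromatic carbon. Among the compounds with values here, no measured step alters a substituent on that aromatic ring, so the measured steps give no direct guide here, and nothing among them points to a change beyond the scatter. Compound 4 is therefore expected to give about 85%, within 65% to 100%. The step of a number 5 percentage points lower from compound 3 to compound 4 (within the scatter) that this estimate means is expected to stay within the scatter.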

Compound 4, a percentage reported as activity, at one concentration (the size of the read-out at that concentration, not a potency): 100%
Compound 4: the middle estimate sits 15 percentage points below what was measured; the measured number falls inside the stated range.
By their numbers in this assay, from the lowest: compound 2; then compounds 3, 1 and 4 (each within the scatter of the next).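

Bromo in place of nitro on the aromatic carbon gives a number 10 percentage points higher from compound 3 to compound 4 (within the scatter) in this assay, the first measured change at this position, so the read-out holds with either group there. The (4-bromophenyl)sulfonyl group stays clear of carbamoyl, a number 40 percentage points higher from compound 2 to compound 4 (beyond the scatter), yet cannot be separated from the group on the amine nitrogen of compound 1, no change at the digits printed from compound 1 to compound 4 (within the scatter). Nothing available explains these steps.

On these data alone, whether an amine or a carboxylic acid on that aromatic carbon would hold the read-out remains open. A single concentration also leaves open how the effects of compound 1, compound 3 and compound 4 compare at any other concentration.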